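A few compounds are considered here, and "the series" means these few. Any claim that something is new, unique, unknown or untested is made for them only; others in the source may bear on it.

Measured so far: compound 1 `CCc1cc(C(C)=O)c(O)cc1OCCCCCCC(C)(C)C#N` gives 65%; compound 2 `CCCc1cc(C(C)=O)c(O)cc1OCCCCCC(=O)O` gives 73%; compound 3 `C=CCc1cc(C(C)=O)c(O)cc1OCCCCCC(C)=O` gives 98%.

In an assay on isolated protein for inhibition of leukotriene B4 receptor 1 (Homo sapiens), tested at 10 uM (on this read-out higher numbers stand for more inhibition at the one concentration tested (going by the name of the read-out) and lower numbers for less inhibition), compound 1 stands lowest of the three numbers. Compound 2 lies nearest to it, within the scatter, while compound 3 lies beyond the scatter above it. The step to compound 4 `CCc1cc(C(C)=O)c(O)cc1OCCCCCCC(=O)N(C)C` changes only the end of the chain: dimethylcarbamoyl in place of 1-cyano-1-methylethyl on a saturated chain carbon, six bonds along the chain from an oxygen on an aromatic ring. Within the data shown here, no step between measured compounds that differ in one place is known, so the expectation for compound 4 rests only on where compound 1 sits and on the values of compound 2 and compound 3, both carrying a carbonyl at the chain end. The step from compound 1 to compound 4 is expected to be a modest rise, a number 10 percentage points higher from compound 1 to compound 4 (within the scatter). Compound 4 is therefore estimated at 75%, within 55% to 92%.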

Compound 4, a percentage reported as inhibition, at one concentration (the size of the read-out at that concentration, not a potency): 100%
Compound 4: the middle estimate sits 25 percentage points below what was measured; measured number above the stated range.
By their numbers in this assay, from the lowest: compounds 1 and 2 (each within the scatter of the next); then compounds 3 and 4 (each within the scatter of the next).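

In this assay, dimethylcarbamoyl in place of 1-cyano-1-methylethyl at this chain end gives a number 35 percentage points higher from compound 1 to compound 4 (beyond the scatter), so the group on this saturated chain carbon affects the read-out. The two groups match in heavy atoms, hydrogen-bond donors and hydrogen-bond acceptors, so these counts do not separate them. No measurement here accounts for the rise. As far as these compounds go, whether an unsubstituted amide, a methyl ester or a shorter chain would keep the number at this place stays open. Potency also stays open, as a single-concentration read-out does not give it.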